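Weak Antiproliferative Effects in a Small Series

A few compounds are considered here, and "the series" means these few. Any claim that something is new, unique, unknown or untested is made for them only; others in the source may bear on it.

Three measured compounds share one core and differ only in the group carried by the outer aromatic ring. Compound 1 `COc1cc(OC)c2c(=O)cc(-c3ccc(OCCBr)cc3)oc2c1` is recorded in a functional assay (Homo sapiens) for antiproliferative activity, read by resazurin assay, with a stated time of 48 h, tested at 10 uM (on this read-out lower numbers stand for a weaker effect and higher numbers for a stronger effect at the one concentration tested), as "not active" (no number reported). Compound 2 `COc1cc(OC)c2c(=O)cc(-c3ccc(OCCF)cc3)oc2c1` is likewise recorded in this assay as "not active" (no number reported). For the measured compounds named here, compound 3 `COc1cc(OC)c2c(=O)cc(-c3ccc(-c4ccc(F)nc4)cc3)oc2c1` gives 6% in this assay, the only number reported among the three and a weak effect. Compound 4 `COc1cc(OC)c2c(=O)cc(-c3ccc(NCCN(C)C)cc3)oc2c1` has not been measured; it differs from compound 3 by (2-(dimethylamino)ethyl)amino in place of 6-fluoropyridin-3-yl on an aromatic carbon. Going by the values given here, no step between two measured compounds is available to guide the forecast. Given that compound 3 sits at 6%, the step from compound 3 to compound 4 is expected to be a number 4 percentage points higher from compound 3 to compound 4 (within the scatter), within the usual scatter. Compound 4 is therefore expected to give about 10%, between 0% and 30%.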

Compound 4, a percentage reported as inhibition, at one concentration (the size of the read-out at that concentration, not a potency): 60%
Compound 4: the middle estimate sits 50 percentage points below what was measured, and the stated range ends below it.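

Putting (2-(dimethylamino)ethyl)amino in place of 6-fluoropyridin-3-yl gives a number 54 percentage points higher from compound 3 to compound 4 (beyond the scatter) in this assay. The earlier compounds shown here offered no step, whereas this one shows that the group on this aromatic carbon, para to a large group, can strongly change the effect at the one concentration tested. Nothing available explains the gain.

The change removes a ring and adds an open chain with two nitrogens, so the part responsible remains unclear. A longer chain, a morpholine ring or a carboxylic acid at this place could help separate these features.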